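The source may report more compounds than this note shows. Statements on the series, on what has been measured and on what is new or still open speak of the compounds shown alone.

Measured so far in an assay on HEK293 cells for agonist activity at transient receptor potential cation channel subfamily M member 8 (Homo sapiens), read by fluorescence and calcium flux, with a stated time of 5 min; a higher number here means that more compound is needed for the effect, a lower number that less compound is needed:

compound 1, `C=CCc1cc(OC)c(O[C@H](C)[C@@H](O)c2ccc(OC)c(OC)c2)c(OC)c1` — > 10000 nM
compound 2, `C=CCc1cc(OC)c(OC(C)C(OCCOCCCC)c2ccc(O)c(OC)c2)c(OC)c1` — 153 nM
compound 3, `C=CCc1cc(OC)c(O[C@@H](C)[C@@H](OCC)c2ccc(O)c(OC)c2)c(OC)c1` — 87 nM

The value of compound 1 is a limit of the assay, not a number; this is the limit of > 10000 nM in this assay, at which 1 of the 3 values shown sits. Two numbers remain. Compound 2 and compound 3 sit within the usual scatter of each other, so no order is drawn between them; compound 2 simply carries the larger of the two numbers shown.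

Compound 4, `C=CCc1cc(OC)c(OC(C)C(OCCCCCC)c2ccc(O)c(OC)c2)c(OC)c1`, is not yet measured. It differs from compound 2 by butyl in place of butoxy on a saturated chain carbon, two bonds along the chain from an oxygen on a saturated carbon; cut one bond further out the same difference reads 2-butoxyethoxy to hexyloxy.

No measured step of this kind stands in the series, so nothing shown fixes its size. Compound 3 with ethoxy and compound 2 with 2-butoxyethoxy give numbers within the scatter of each other, which points to a small step from compound 2 to compound 4 , in either direction or none beyond the scatter. Compound 4 is expected to give 150 nM in this assay, with a range of 45 nM to 500 nM, the expected step being a 1.0-fold lower number from compound 2 to compound 4 (0.01 log units; within the scatter).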

Compound 4, half-maximal effective concentration: 329 nM
For compound 4 the middle estimate is 2.2-fold (0.34 log units) below the measured one, and the stated range covers the measured number.
By their numbers in this assay, from the lowest: compounds 3 and 2 (each within the scatter of the next); then compound 4. At a limit, above all of these: compound 1.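

In this assay, the series now has its first readable step at this position: butyl in place of butoxy on a saturated chain carbon, two bonds along the chain from an oxygen on a saturated carbon, gives a 2.2-fold higher number from compound 2 to compound 4 (0.33 log units; beyond the scatter). The step is modest, but it shows that 2-butoxyethoxy and hexyloxy are not interchangeable here, although the change leaves the chain without its hydrogen-bond acceptor and one heavy atom shorter and compound 4 still gives a measured number, 329 nM, rather than a limit. Nothing measured on these compounds bears on why the number moves with this change, so the step stands as an observation on one pair.

This single pair cannot separate the loss of the chain oxygen from the change of one heavy atom, and it gives no sign of whether the same step would hold on a different chain length or with the stereocentres defined. Also open, going by these compounds, is how a terminal amine, a terminal carboxylic acid or a longer chain with a second ether oxygen would behave at this position.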